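Permeability notes on the two-ring series

This account rests on a few compounds, and the source may have more. Where it says the series, first, only, none or still open, it means among the compounds named here.

Measured so far in an ADME assay for permeability, using PAMPA, with a stated time of 30 min, at pH 7.4; a lower number here means that the compound crosses the layer more slowly, a higher number that the compound crosses the layer faster:
- compound 1 `N=c1c2c(-c3ccccc3)c(-c3ccccc3)n(CC3CCCCC3)c2ncn1[C@H]1CC[C@H](O)CC1`: "nd" (no result reported)
- compound 2 `Cc1c(C)n(Cc2ccccc2)c2ncn([C@H]3CC[C@H](O)CC3)c(=N)c12`: < 1 10^-6 cm/s
- compound 3 `COc1ccc(Cn2c(-c3ccccc3)c(-c3ccccc3)c3c(=N)n([C@H]4CC[C@H](O)CC4)cnc32)cc1`: > 1000 10^-6 cm/s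

Compound 2 stands at the lower end of what is shown: its value in this assay is a limit, not a number (the limit of < 1 10^-6 cm/s in this assay, at which 1 of the 3 values shown sits). Compound 3 sits at the opposite limit (the limit of > 1000 10^-6 cm/s in this assay, at which 1 of the 3 values shown sits). Compound 1 has no result. Within the data shown here, no pair of measured compounds differs in only one place, so no measured step is available to anchor the next one.

Compound 4 `Cc1c(C)n(Cc2ccccc2)c2ncn(C3CCOCC3)c(=N)c12` differs from compound 2 in one place: oxan-4-yl in place of 4-hydroxycyclohexyl on an aromatic nitrogen.

Since compound 2 only gives a limit, the size of the step is open; a modest rise is expected, an at least 5.0-fold higher number from compound 2 to compound 4 (0.69 log units; beyond the scatter), with the upper part of the range possible. Compound 4 is expected at 5 10^-6 cm/s, between 1 10^-6 cm/s and 30 10^-6 cm/s, and a limit rather than a number remains a real possibility.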

Compound 4, apparent permeability: 1680 10^-6 cm/s
The estimate for compound 4 lay 340-fold (2.53 log units) below the measured number, and the stated range ends below it.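

On this aromatic nitrogen, oxan-4-yl in place of 4-hydroxycyclohexyl gives an at least 1600-fold higher number from compound 2 to compound 4 (3.22 log units; beyond the scatter) in this assay, so this position can move the read-out strongly with the rest of the structure unchanged. The change goes from 1 hydrogen-bond donor to 0 hydrogen-bond donors, with 1 hydrogen-bond acceptor on both groups. The step has only a lower bound, as compound 2 is a limit and not a number: the limit of < 1 10^-6 cm/s in this assay, at which 1 of the 4 values shown sits.

The compounds shown do not separate the donor count from the other differences between the two groups, and a basic amine such as piperidin-4-yl at this position remains untested here. From the compounds shown here alone, whether the step carries over to the cores of compound 1 and compound 3 also stays open.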